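Ring-nitrogen substituent in the shared core: compound 4

The compounds below may be only part of what the source reports. "The series", "measured", "known", "first", "only" and "open" are said of these compounds alone.

Compound 1 `CC(C)c1onc(-c2c(Cl)cccc2Cl)c1COc1ccc(-c2nc3ccc(C(=O)O)cc3n2C)cc1` carries a methyl on the ring nitrogen of the shared core, and in an assay on HEK-293T cells for antagonist activity at vitamin D3 receptor (Homo sapiens), read by a luciferase reporter, with a stated time of 24 h (a lower number here means a stronger inhibitor, a higher number a weaker inhibitor), compound 1 gives 7150 nM, the highest number of the three measured, so it is the weakest inhibitor here. Compound 2 `CC(C)c1onc(-c2c(Cl)cccc2Cl)c1COc1ccc(-c2nc3ccc(C(=O)O)cc3n2Cc2ccc(F)cc2)cc1` gives 1140 nM and compound 3 `CCCn1c(-c2ccc(OCc3c(-c4c(Cl)cccc4Cl)noc3C(C)C)cc2)nc2ccc(C(=O)O)cc21` gives 1400 nM. Both enlarge the group on the saturated chain carbon bound to the aromatic nitrogen: a 6.3-fold lower number from compound 1 to compound 2 (0.80 log units; beyond the scatter), and a 5.1-fold lower number from compound 1 to compound 3 (0.71 log units; beyond the scatter). Between those two the difference is small, a 1.2-fold higher number from compound 2 to compound 3 (0.09 log units; within the scatter).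

Compound 4 `CC(=O)N1CCC(n2c(-c3ccc(OCc4c(-c5c(Cl)cccc5Cl)noc4C(C)C)cc3)nc3ccc(C(=O)O)cc32)CC1` changes the same position: 1-acetylpiperidin-4-yl in place of methyl on an aromatic nitrogen. Among the compounds with values here, the group entering is larger than either of those in compound 2 or compound 3, and both of those enlargements lowered the number beyond the scatter, so a modest lowering of similar size is expected for compound 4, though no measured step carries a saturated ring with an acetyl on the ring nitrogen. Compound 4 is expected to give 1800 nM, within a range of 700 nM to 4500 nM. That expectation means a 4.0-fold lower number from compound 1 to compound 4 (0.60 log units; beyond the scatter).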

Compound 4, half-maximal inhibitory concentration: > 10000 nM
Compound 4 gave a limit, no number (the forecaster's own chance of this, stated with the estimate: 5%); at least 5.5-fold (0.74 log units) between middle value and limit.
By their numbers in this assay, from the lowest: compounds 2 and 3 (each within the scatter of the next); then compound 1. At a limit, above all of these: compound 4.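

Compound 4 stands at a limit and not at a number, so it is bounded on one side only: the limit of > 10000 nM in this assay, at which 1 of the 4 values shown sits. Enlarging the group on the aromatic nitrogen therefore does not lower the number in every case: 1-acetylpiperidin-4-yl gives an at least 7.1-fold higher number from compound 3 to compound 4 (0.85 log units; beyond the scatter) and an at least 8.7-fold higher number from compound 2 to compound 4 (0.94 log units; beyond the scatter). Against methyl the change gives no order: an at least 1.3-fold higher number from compound 1 to compound 4 (0.14 log units; that floor lies within the scatter), so compound 4 is not shown to be a weaker inhibitor than compound 1.

Still open, on these data alone, is whether the six-membered non-aromatic ring or the acetyl group accounts for this reversal, and a cyclohexyl group or an unacylated piperidin-4-yl on this nitrogen would separate the two. As far as these compounds go, the true value of compound 4 also remains open, as does the size of its gap from compound 1.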